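Allyloxy chain in place of a bromoalkoxy chain

The compounds below may be only part of what the source reports. "The series", "measured", "known", "first", "only" and "open" are said of these compounds alone.

Compound 3 `O=c1c(-c2ccc(O)cc2)coc2cc(OCCCBr)ccc12` gives 90.8% in a functional assay on mitochondria (Cricetulus griseus) for inhibition of Monoamine oxidase (Homo sapiens), tested at 3 uM; on this read-out higher numbers stand for a stronger effect at the one concentration tested and lower numbers for a weaker effect. Its number lies between those of compound 1 `CCOc1ccc2c(=O)c(-c3ccc(O)cc3)coc2c1`, which gives 95.6%, and compound 2 `O=c1c(-c2ccc(O)cc2)coc2cc(OCCCCBr)ccc12`, which gives 84.7%. The steps of a number 4.8 percentage points lower from compound 1 to compound 3 (within the scatter) and a number 6.1 percentage points higher from compound 2 to compound 3 (within the scatter) both stay within the scatter, so these three compounds cannot be ranked against one another. Compound 4 `C=CCOc1ccc2c(=O)c(-c3ccc(O)cc3)coc2c1` carries vinyl in place of 2-bromoethyl on a saturated chain carbon bound to an oxygen on an aromatic ring. Among the compounds with values here, three measured steps bear on this change, since each alters the same chain on the shared core: a number 4.8 percentage points lower from compound 1 to compound 3 (within the scatter), a number 6.1 percentage points higher from compound 2 to compound 3 (within the scatter) and a number 10.9 percentage points lower from compound 1 to compound 2 (beyond the scatter). Only the last exceeds the scatter, and only modestly; like compound 1, compound 4 carries no bromine on that chain, and compound 1 shows the highest number of the three. The expected outcome is therefore a number 1.2 percentage points higher from compound 3 to compound 4 (within the scatter), a step that would remain within the scatter. Compound 4 is estimated to give 92%, with a likely range from 83% to 98%.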

Compound 4, a percentage reported as inhibition, at one concentration (the size of the read-out at that concentration, not a potency): 89.3%
The estimate for compound 4 lay 2.7 percentage points above the measured number; measured number inside the range.
By their numbers in this assay, from the lowest: compounds 2, 4, 3 and 1 (each within the scatter of the next, the first and the last beyond it).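

In this assay, the change from 3-bromopropoxy to allyloxy gives a number 1.5 percentage points lower from compound 3 to compound 4 (within the scatter), so a chain with a double bond and no bromine can stand in this place without a change that can be told from the scatter. The two other steps, a number 4.6 percentage points higher from compound 2 to compound 4 (within the scatter) and a number 6.3 percentage points lower from compound 1 to compound 4 (within the scatter), also stay within the scatter, so compound 4 cannot be ranked against any of the three earlier compounds, even though compound 1 and compound 2 are separated by more than the scatter. No measurement here offers an explanation for these results.

From the compounds shown here alone, what an amine or a carboxylic acid would do on this chain remains open. With one concentration per compound, these numbers tell only of a stronger or weaker effect at that concentration.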